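Aryl sulfonamide series: cytotoxicity outlook for compound 4

The source may report more compounds than this note shows. Statements on the series, on what has been measured and on what is new or still open speak of the compounds shown alone.

The three measured compounds share a core carrying a sulfonyl group on a ring nitrogen. Compound 1 `Cc1nc(Cl)sc1S(=O)(=O)N1CCC(N2CCC(C)CC2)CC1` has been run in an ADME assay on HCT-116 cells (Homo sapiens) for cytotoxicity, read by CellTiter-Glo, with a stated time of 72 h; on this read-out higher numbers stand for weaker inhibition and lower numbers for stronger inhibition; in that assay compound 1 gives > 10000 nM, which is a limit rather than a number. Compound 2 `CC1CCN(C2CCN(S(=O)(=O)c3ccc(Cl)c(Cl)c3)CC2)CC1` in this assay gives > 5000 nM, again a limit. Compound 3 `CC1CCN(C2CCN(S(=O)(=O)c3ccc(Cl)c(C(F)(F)F)c3)CC2)CC1` in this assay gives > 5000 nM, also a limit. Compound 2 thus stands at one of the two limits in the set, and no measured number separates it from the others. The step that the two limits leave unreadable from compound 1 to compound 2 and the step that the two limits leave unreadable from compound 2 to compound 3 cannot be read in size because the limit of > 10000 nM in this assay, at which 1 of the 3 values shown sits, and the limit of > 5000 nM in this assay, at which 2 of the 3 values shown sit, cover all three values.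

Compound 4 `CC1CCN(C2CCN(S(=O)(=O)c3cc(Cl)cc(Cl)c3)CC2)CC1` differs from compound 2 by 3,5-dichlorophenyl in place of 3,4-dichlorophenyl on a sulfonyl sulfur. Neither measured step bears on this change in a readable way, so no step beyond the scatter can be foreseen in this assay. Compound 4 is expected to give 10000 nM, within a range from 3000 nM to 40000 nM. The expected step that the limit leaves unreadable from compound 2 to compound 4 is accordingly estimated as none beyond the scatter, most likely ending again at a limit.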

Compound 4, half-maximal inhibitory concentration: > 5000 nM
Compound 4: a limit, no number (the forecaster's own chance of this, stated with the estimate: 80%); the middle value is on the limit's open side.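

Neither the step to compound 4 from compound 1 nor the step to it from compound 2 can be read in this assay, since each of the three values is a limit. No compound shown gives a number in this assay, which leaves open whether 3,5-dichlorophenyl and 3,4-dichlorophenyl differ at all.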